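The source may report more compounds than this note shows. Statements on the series, on what has been measured and on what is new or still open speak of the compounds shown alone.

Among the compounds with values here, in a functional assay on SU-DHL-6 cells (Homo sapiens) for antiproliferative activity, read by MTT assay (a lower number here means a stronger inhibitor, a higher number a weaker inhibitor), compound 1 `COc1ncc(-c2ccc3ncnc(N[C@H]4CCCN(C(=O)CCBr)C4)c3c2)cc1C#N` gives 15 nM, and compound 2 `COc1ncc(-c2ccc3ncnc(N[C@H]4CCCN(C(=O)c5cccnc5)C4)c3c2)cc1C#N` gives 120 nM, the higher of the two numbers so far. Compound 3 `COc1ncc(-c2ccc3ncnc(N[C@H]4CCCN(C(=O)CN(C)C)C4)c3c2)cc1C#N` differs from compound 2 in one place: (dimethylamino)methyl in place of pyridin-3-yl on a carbonyl carbon, with (dimethylamino)methyl in place of pyridin-3-yl on a carbonyl carbon. Within the data shown here, only one measured step changes this same place, an 8.0-fold higher number from compound 1 to compound 2 (0.90 log units; beyond the scatter), and it is modest. It gives no firm direction for the new group, so no change beyond the scatter is expected in this assay. The expected change is a 1.5-fold lower number from compound 2 to compound 3 (0.18 log units; within the scatter). For compound 3 the estimated value is 80 nM, with an expected range of 25 nM to 260 nM.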

Compound 3, half-maximal inhibitory concentration: 160 nM
For compound 3 the middle estimate is 2.0-fold (0.30 log units) below the measured one; measured number inside the range.
By their numbers in this assay, from the lowest: compound 1; then compounds 2 and 3 (each within the scatter of the next).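

At this carbonyl carbon, in this assay, the step of a 1.3-fold higher number from compound 2 to compound 3 (0.12 log units; within the scatter) shows that (dimethylamino)methyl, with no ring, and pyridin-3-yl cannot be told apart. The step of an 11-fold higher number from compound 1 to compound 3 (1.03 log units; beyond the scatter) sets 2-bromoethyl apart from both of these groups, and it is the only one of the three to stand apart. No supporting data bear on why this gap appears.

On these data alone, whether the gap belongs to the bromine or to the saturated chain stays open. A 2-chloroethyl or plain ethyl group on the same carbonyl carbon would separate the two.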